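Tolerance limits from compound 3 to compound 4

The source may report more compounds than this note shows. Statements on the series, on what has been measured and on what is new or still open speak of the compounds shown alone.

Measured in an ADME assay on cells (Peritoneal macrophage cell, Mus musculus) for cytotoxicity, read by fluorescence and resazurin assay, with a stated time of 3 days; a lower number here means that less compound is tolerated, a higher number that more compound is tolerated (all three readings are limits):
- compound 1 `CC(C)Oc1cc(C(=O)Nc2cc(-c3ccccn3)n[nH]2)cc(C(=O)N2CCCC2)c1` gives > 40300 nM (a limit)
- compound 2 `O=C(Nc1[nH]nc(-c2ccccn2)c1C1CC1)c1ccccc1F` gives > 64000 nM (a limit)
- compound 3 `O=C(Nc1cc(-c2ccccn2)n[nH]1)N1CCC(c2cccc(F)c2)CC1` gives > 45000 nM (a limit)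

Compound 3 has no exact value on these numbers, and its reading is the limit of > 45000 nM in this assay, at which 1 of the 3 values shown sits, as its position. All three readings are limits. The compounds cannot be placed in order.

Compound 4 `N#Cc1ccc(C2CCN(C(=O)Nc3cc(-c4ccccn4)n[nH]3)CC2)cc1` has not yet been measured. It differs from compound 3 by 4-cyanophenyl in place of 3-fluorophenyl on a saturated ring carbon (in words, 4-cyanophenyl in place of 3-fluorophenyl on a saturated ring carbon of a six-membered non-aromatic ring with 1 nitrogen). The rest of the structure is unchanged.

Within the data shown here, the series offers no measured step of any size for this change. In this assay no step beyond the usual scatter is expected, in either direction. This expectation rests on compound 3 with its limit of > 45000 nM and on the absence of any exact reading among the measured compounds. The expected result is a number no higher from compound 3 to compound 4 (the limit leaves the size open) as an estimate only. For compound 4 the estimated half-maximal cytotoxic concentration is 45000 nM within an expected range of 20000 nM to 80000 nM and the reading is expected to be a limit again.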

Compound 4, half-maximal cytotoxic concentration: > 64000 nM
Compound 4: only a limit was reported; the forecaster's own chance of this, stated with the estimate: 75%; middle value at least 1.4-fold (0.15 log units) from the limit.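

Compound 3 and compound 4 both stand as limits in this assay, so no step can be read between them. The compounds shown leave open the size and direction of any effect of 4-cyanophenyl in place of 3-fluorophenyl on a saturated ring carbon, and the order of all four compounds, none of which has an exact value.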